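Replacing the benzoxazolylsulfanyl arm of compound 1 with phenylpiperazine

The source may hold more compounds than are shown below. What is called first, only, known or untested is meant among the compounds shown, and "the series" means these compounds.

Compound 1 `Cn1c(-c2ccc(NC(=O)CSc3nc4cc(Cl)ccc4o3)cc2)nc(-c2ccccc2)c1-c1ccccc1` carries a (5-chloro-1,3-benzoxazol-2-yl)sulfanyl group on a saturated chain carbon bound to a carbonyl carbon. In a functional assay on HT-29 cells (Homo sapiens) for cytotoxicity, read by MTT assay, with a stated time of 24 h (on this read-out lower numbers stand for stronger inhibition and higher numbers for weaker inhibition), compound 1 gives 20.6 ug/mL, the lowest of the three numbers measured. Its closest neighbour is compound 2 `CN1CCN(CC(=O)Nc2ccc(-c3nc(-c4ccccc4)c(-c4ccccc4)n3C)cc2)CC1`, which in this assay gives 35.5 ug/mL; the step is a 1.7-fold higher number from compound 1 to compound 2 (0.24 log units; within the scatter). Compound 3 `CCN1CCN(CC(=O)Nc2ccc(-c3nc(-c4ccccc4)c(-c4ccccc4)n3C)cc2)CC1` in this assay gives 75 ug/mL, and the step is a 3.6-fold higher number from compound 1 to compound 3 (0.56 log units; beyond the scatter). Between the two piperazines the step is a 2.1-fold higher number from compound 2 to compound 3 (0.32 log units; beyond the scatter).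

Compound 4 `Cn1c(-c2ccc(NC(=O)CN3CCN(c4ccccc4)CC3)cc2)nc(-c2ccccc2)c1-c1ccccc1` is reached from compound 1 by a single change: 4-phenylpiperazin-1-yl in place of (5-chloro-1,3-benzoxazol-2-yl)sulfanyl on a saturated chain carbon bound to a carbonyl carbon. The two measured steps that bear on it are those from compound 1 to the piperazine amides, one within the scatter and one modest but beyond it. Both point toward a higher number, and the phenylpiperazine of compound 4 is the third member of the same series. A step of similar size is therefore expected, in the direction of a higher number, with the estimated step being a 1.8-fold higher number from compound 1 to compound 4 (0.27 log units; within the scatter). Compound 4 is thus expected to give about 38 ug/mL in this assay, within a range from 15 ug/mL to 90 ug/mL.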

Compound 4, half-maximal inhibitory concentration: 8.6 ug/mL
For compound 4 the middle estimate is 4.4-fold (0.65 log units) above the measured one, outside the stated range (below it).
By their numbers in this assay, from the lowest: compound 4; then compounds 1 and 2 (each within the scatter of the next); then compound 3.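

In this assay, the group on the saturated chain carbon bound to a carbonyl carbon can also lower the number: 4-phenylpiperazin-1-yl in place of (5-chloro-1,3-benzoxazol-2-yl)sulfanyl gives a 2.4-fold lower number from compound 1 to compound 4 (0.38 log units; beyond the scatter) here, whereas the 4-methylpiperazin-1-yl of compound 2 stayed within the scatter of compound 1 and the 4-ethylpiperazin-1-yl of compound 3 gave a higher number. What the piperazine carries on its amine nitrogen therefore counts in this series, with phenyl in place of methyl giving a 4.1-fold lower number from compound 2 to compound 4 (0.62 log units; beyond the scatter) and phenyl in place of ethyl giving an 8.7-fold lower number from compound 3 to compound 4 (0.94 log units; beyond the scatter) in the same assay. The piperazine ring alone does not set the number, and compound 4 is the only one of the four whose steps to all the others lie beyond the scatter. Nothing at hand accounts for this difference.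

The compounds shown leave open whether a benzyl group, a pyridine ring or a chlorophenyl group on the same amine nitrogen would give a similar number. They also leave open whether the step would hold with a morpholine ring or a longer chain at this place.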